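Fluorine to methyl on the cyclopropyl amide

The source may hold more compounds than are shown below. What is called first, only, known or untested is meant among the compounds shown, and "the series" means these compounds.

Compound 1 `CC(=O)N1CC2CC(C1)N2` gives 95% in an assay on SH-EP1 cells for agonist activity at Neuronal acetylcholine receptor; alpha4/beta2 (Homo sapiens), read by FLIPR and calcium flux; a higher number here means a larger maximal response, a lower number a smaller maximal response. Compound 2 `CCCC(=O)N1CC2CC(C1)N2` gives 110% in this assay, and compound 3 `O=C([C@H]1C[C@@H]1F)N1CC2CC(C1)N2` gives 100% in this assay. Compound 3 sits among the three by two steps, a number 5 percentage points higher from compound 1 to compound 3 (within the scatter) and a number 10 percentage points lower from compound 2 to compound 3 (within the scatter); its number lies between those of compound 1 and compound 2, and all three fall within the usual scatter of one another. Going by the values given here, the one step beyond the scatter in the set is a number 15 percentage points higher from compound 1 to compound 2 (beyond the scatter).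

Compound 4 `C[C@@H]1C[C@@H]1C(=O)N1CC2CC(C1)N2` differs from compound 3 by a group of 4 heavy atoms (4 carbon; one three-membered non-aromatic ring of carbon only) in place of a group of 4 heavy atoms (3 carbon, 1 fluorine; one three-membered non-aromatic ring of carbon only), on a carbonyl carbon. Among the compounds with values here, no measured step replaces a 2-fluorocyclopropyl with another three-membered ring; the nearest comparisons are the exchanges of the whole group on the carbonyl carbon, a number 5 percentage points higher from compound 1 to compound 3 (within the scatter) and a number 10 percentage points lower from compound 2 to compound 3 (within the scatter), both within the scatter, which leave the maximal response near the level of compound 3. The expectation is therefore for no change beyond the scatter, a number 2 percentage points higher from compound 3 to compound 4 (within the scatter). Compound 4 is estimated at 102% in this assay, with a range from 85% to 120%.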

Compound 4, largest response reached (Emax), in percent of the reference or control that the assay uses: 97%
Estimate against measurement, compound 4: 5 percentage points above; the range from low to high includes it.
By their numbers in this assay, from the lowest: compounds 1, 4, 3 and 2 (each within the scatter of the next, the first and the last beyond it).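

Going by these compounds alone, on the carbonyl carbon, the fluorine on the three-membered ring can give way to a carbon group with no change beyond the scatter in this assay: a number 3 percentage points lower from compound 3 to compound 4 (within the scatter) is the first exchange that keeps the ring in place. The open-chain comparisons divide, with a number 13 percentage points lower from compound 2 to compound 4 (beyond the scatter) as a modest step beyond the scatter and a number 2 percentage points higher from compound 1 to compound 4 (within the scatter) within it, so compound 4 sits apart from the propyl amide compound 2 in a way compound 3 does not. No measurement here offers an explanation for these steps.

Still open, on these data alone, is how the maximal response behaves with a cyclobutyl ring, or with a hydroxyl or an amine on the three-membered ring. The other stereoisomers of the substituted cyclopropyl ring also remain to be compared.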